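A few compounds are considered here, and "the series" means these few. Any claim that something is new, unique, unknown or untested is made for them only; others in the source may bear on it.

Of the compounds shown here, two have so far been measured in an assay on isolated protein for inhibition of kynurenine 3-monooxygenase (Rattus norvegicus); on this read-out higher numbers stand for weaker inhibition and lower numbers for stronger inhibition. Compound 1 `O=[N+]([O-])c1cccc(-c2csc(NS(=O)(=O)c3ccc(Cl)c(Cl)c3)n2)c1` gives 120 nM. Compound 2 `Cc1ccc(S(=O)(=O)Nc2nc(-c3ccc(O)c(C)c3)cs2)cc1` differs from compound 1 in several places. In this assay compound 2 gives 114 nM. These two numbers lie within the usual scatter of each other, so compound 1 stands on a par with compound 2 and no order can be read from the pair.

Compound 3 `O=[N+]([O-])c1cccc(-c2csc(NS(=O)(=O)c3ccc(Cl)cc3)n2)c1` has not yet been measured in this assay. It differs from compound 1 in a single place: hydrogen in place of chloro on an aromatic carbon. Cut one bond further out, the same change reads 3,4-dichlorophenyl to 4-chlorophenyl. Among the compounds with values here, no measured pair of compounds shows this change, so no step is available for direct comparison, and the expectation rests on the size of the change alone: one heavy atom leaves the six-membered aromatic ring of carbon only and a hydrogen enters. The step from compound 1 to compound 3 is expected to be a 1.8-fold higher number from compound 1 to compound 3 (0.26 log units; within the scatter), a modest weakening that may not clear the scatter. Compound 3 is therefore estimated to give about 220 nM in this assay, with a range from 100 nM to 500 nM.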

Compound 3, half-maximal inhibitory concentration: 84 nM
The estimate for compound 3 lay 2.6-fold (0.42 log units) above the measured number; measured number below the stated range.
By their numbers in this assay, from the lowest: compounds 3, 2 and 1 (each within the scatter of the next).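

Going from 3,4-dichlorophenyl to 4-chlorophenyl, with hydrogen in place of chloro on an aromatic carbon, gives a 1.4-fold lower number from compound 1 to compound 3 (0.15 log units; within the scatter) in this assay, so the two groups cannot be told apart on this read-out. Compounds 1 and 3 form the first pair shown that differs in one place, which makes this the first direct reading of this position: here, the chloro group that leaves, ortho to a chloro group and meta to a large group, can be lost with no change beyond the scatter. Nothing shown here explains this result.

The compounds shown leave open whether a different group at this position, such as a fluoro group, a methoxy group, an amine or a carboxylic acid, would shift the number beyond the scatter. They also leave open whether the same swap of chloro for hydrogen would give a similar step if the nitro group on the other aromatic ring were replaced by an amine.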